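A few compounds are considered here, and "the series" means these few. Any claim that something is new, unique, unknown or untested is made for them only; others in the source may bear on it.

Compound 3 `CCOC(=O)c1cn(-c2ccc(C(=O)O)cc2)nc1CC(C)C` is known only through a limit. In a toxicity assay on HepG2 2.2.15 cells (Homo sapiens) for cytotoxicity, read by CCK-8 assay, with a stated time of 8 days (a lower number here means that less compound is tolerated, a higher number that more compound is tolerated), compound 3 gives > 100000 nM, which is a limit of the assay and not a number. Compound 1 `CCOC(=O)c1cn(-c2ccc([N+](=O)[O-])cc2)nc1CC(C)C` gives in this assay > 100000 nM, again a limit. Compound 2 `CCOC(=O)c1cn(-c2ccc(F)cc2)nc1CC(C)C` gives in this assay > 100000 nM, also a limit. This is summarised by the limit of > 100000 nM in this assay, at which 3 of the 3 values shown sit, so the steps a step that the two limits leave unreadable from compound 1 to compound 3 and a step that the two limits leave unreadable from compound 2 to compound 3 cannot be sized. The change to compound 4 `CCOC(=O)c1cn(-c2ccc(OC)cc2)nc1CC(C)C` is methoxy in place of carboxy on an aromatic carbon. With every comparison ending at the same limit, no step beyond the scatter is expected, and the step that the limit leaves unreadable from compound 3 to compound 4 is the estimate. Compound 4 is therefore expected to give about 150000 nM in this assay, within 60000 nM to 400000 nM, most likely again reported only as a limit.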

Compound 4, half-maximal cytotoxic concentration: 77100 nM
For compound 4 the middle estimate is 1.9-fold (0.29 log units) above the measured one, and the stated range covers the measured number.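

For the compounds shown here, with methoxy on this aromatic carbon, para to a large group, compound 4 gives 77100 nM in this assay, the only number among the values shown. The steps that can be read are an at least 1.2-fold lower number from compound 3 to compound 4 (0.11 log units; that floor lies within the scatter), an at least 1.2-fold lower number from compound 2 to compound 4 (0.11 log units; that floor lies within the scatter) and an at least 1.2-fold lower number from compound 1 to compound 4 (0.11 log units; that floor lies within the scatter); each is only a floor, and that floor lies within the scatter, so methoxy cannot yet be separated from the other three groups. The steps among the other three compounds still cannot be read: the limit of > 100000 nM in this assay, at which 3 of the 4 values shown sit.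

The compounds shown leave open whether an amine or a hydroxy group at this place would give a number, and whether any group here would produce a step beyond the scatter.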